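Swapping Bromo for Methyl on the Shared Core

The source may hold more compounds than are shown below. What is called first, only, known or untested is meant among the compounds shown, and "the series" means these compounds.

In a functional assay on A549 cells (Homo sapiens) for antiproliferative activity, read by MTT assay, with a stated time of 48 h (a lower number here means a stronger inhibitor, a higher number a weaker inhibitor), compound 3 `Clc1ccc(-c2nn(-c3ccccc3)cc2-c2nc3cc(Br)ccc3[nH]2)cc1` gives 2170 nM. That lies within the scatter of compound 1 `Cc1ccc2[nH]c(-c3cn(-c4ccccc4)nc3-c3ccc(F)cc3)nc2c1` at 1440 nM, and clearly under compound 2 `Clc1ccc(-c2nn(-c3ccccc3)cc2-c2nc3ccccc3[nH]2)cc1` at 5960 nM. Compound 4 `Cc1ccc2[nH]c(-c3cn(-c4ccccc4)nc3-c3ccc(Cl)cc3)nc2c1` differs from compound 3 by methyl in place of bromo on an aromatic carbon, with methyl in place of bromo on an aromatic carbon. Among the compounds with values here, the one measured step on this carbon, bromo in place of hydrogen, is modest: a 2.7-fold lower number from compound 2 to compound 3 (0.44 log units; beyond the scatter). Compound 1 already carries the methyl and gives 1440 nM, though with fluoro where compound 4 has chloro. No shift beyond the scatter is therefore expected in this assay, and the expected step is a 1.1-fold lower number from compound 3 to compound 4 (0.06 log units; within the scatter). The estimate for compound 4 is 1900 nM, with an expected range of 900 nM to 4000 nM.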

Compound 4, half-maximal inhibitory concentration: 4640 nM
Compound 4: middle estimate off by 2.4-fold (0.39 log units), on the low side; the measured number lies above the stated range.
By their numbers in this assay, from the lowest: compounds 1 and 3 (each within the scatter of the next); then compounds 4 and 2 (each within the scatter of the next).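

At this aromatic carbon, methyl does not reproduce bromo in this assay: the swap gives a 2.1-fold higher number from compound 3 to compound 4 (0.33 log units; beyond the scatter) and, set against hydrogen, methyl gives a 1.3-fold lower number from compound 2 to compound 4 (0.11 log units; within the scatter) here. With methyl held fixed, the halogen elsewhere also matters, since chloro in place of fluoro gives a 3.2-fold higher number from compound 1 to compound 4 (0.51 log units; beyond the scatter) and the low number of compound 1 does not carry over. Nothing available explains either shift. Still open, as far as these compounds go, is whether bromo would help as much alongside fluoro, and how a larger group such as methoxy or an amine would read on this carbon.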